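Replacing bromo with trifluoromethoxy in an antiproliferative series

This account rests on a few compounds, and the source may have more. Where it says the series, first, only, none or still open, it means among the compounds named here.

- compound 1 `OC[C@H]1O[C@@H](n2cnc3c(NCc4ccccc4Br)ncnc32)[C@H](O)[C@@H]1O` gives 10000 nM in a functional assay on K562 cells (Homo sapiens) for antiproliferative activity, with a stated time of 72 h; on this read-out higher numbers stand for weaker inhibition and lower numbers for stronger inhibition
- compound 2 `COc1cccc(CNc2ncnc3c2ncn3[C@@H]2O[C@H](CO)[C@@H](O)[C@H]2O)c1OC` gives > 166000 nM as a limit

Compound 1 holds the only number shown, and the one other entry is a limit. Compound 3 `OC[C@H]1O[C@@H](n2cnc3c(NCc4ccccc4OC(F)(F)F)ncnc32)[C@H](O)[C@@H]1O` awaits measurement and carries trifluoromethoxy in place of bromo on an aromatic carbon, ortho to a large group (trifluoromethoxy in place of bromo on an aromatic carbon). Resting on compound 2 and its step (an at least 16-fold higher number from compound 1 to compound 2 (1.22 log units; beyond the scatter)), which is large, beyond the scatter and ends at a limit (the limit of > 166000 nM in this assay, at which 1 of the 2 values shown sits), a smaller step toward higher numbers is expected in this assay for this single exchange. The expected step is a 2.0-fold higher number from compound 1 to compound 3 (0.30 log units; within the scatter) as an estimate. Compound 3 is estimated at 20000 nM (expected range 5000 nM to 100000 nM).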

Compound 3, half-maximal inhibitory concentration: 81400 nM
For compound 3 the middle estimate is 4.1-fold (0.61 log units) below the measured one; measured number inside the range.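

Exchanging only the bromo for trifluoromethoxy on the aromatic carbon, ortho to a large group, gives an 8.1-fold higher number from compound 1 to compound 3 (0.91 log units; beyond the scatter) in this assay. A change at this one place, with the ring otherwise untouched, is therefore enough to weaken inhibition beyond the scatter, and it yields a measured number. The entry for compound 2 remains a limit: the limit of > 166000 nM in this assay, at which 1 of the 3 values shown sits.

Going by these compounds, whether a smaller group here, such as fluoro or methyl, would hold the value of compound 1 stays open. So does the effect of an amine at this place.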